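Phenoxy swap at the shared core: dichloro to fluoro

The source may report more compounds than this note shows. Statements on the series, on what has been measured and on what is new or still open speak of the compounds shown alone.

Among the measured compounds shown here, compound 1 `Nc1cc(N)c2nc(-c3ccccc3)c(Oc3ccc(Cl)c(Cl)c3)nc2c1` is one of two compounds measured in a functional assay on NCI-H226 cells (Homo sapiens) for inhibition, read by sulforhodamine B assay, with a stated time of 48 h; a higher number here means a weaker inhibitor of growth, a lower number a stronger inhibitor of growth; compound 1 gives 49000 nM. The other, compound 2 `CCOC(=O)[C@H](CCC(=O)O)NC(=O)c1ccc(Sc2nc3cc(N)cc(N)c3nc2-c2ccccc2)cc1`, gives in this assay 43700 nM; the two values lie within the scatter of each other, so no order between compound 1 and compound 2 can be read from them. Compound 3 `Nc1cc(N)c2nc(-c3ccccc3)c(Oc3ccc(F)cc3)nc2c1` has not yet been measured. It differs from compound 1 by 4-fluorophenyl in place of 3,4-dichlorophenyl on an oxygen on an aromatic ring. For the measured compounds named here, no step between measured compounds bears on this change, and both measured values sit in the same weak region, so the expected step for compound 3 in this assay is small, if anything toward a higher number, and may not exceed the scatter. The step from compound 1 to compound 3 is estimated at a 1.2-fold higher number from compound 1 to compound 3 (0.09 log units; within the scatter). For compound 3 the estimate in this assay is 60000 nM, with a range from 25000 nM to 140000 nM.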

Compound 3, concentration for total growth inhibition: 49000 nM
The estimate for compound 3 lay 1.2-fold (0.09 log units) above the measured number, and the stated range covers the measured number.
By their numbers in this assay, from the lowest: compounds 2, 1 and 3 (each within the scatter of the next).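

In this assay, among the compounds shown here, the first step at this position between compounds that differ in one place reads no change at the digits printed from compound 1 to compound 3 (within the scatter) and concerns 4-fluorophenyl in place of 3,4-dichlorophenyl on the oxygen. In this assay, for the compounds shown here, both chlorines on that ring can therefore give way to a single fluorine with no step that can be read, which the earlier comparison of compound 1 and compound 2, differing in more than one place, could not show. Nothing at hand gives a reason for this result.

Still open, as far as these compounds go, is whether an unsubstituted phenyl, or a phenyl carrying a methoxy group, an amine or a carboxylic acid, would give a readable step on this oxygen. From the compounds shown here alone, a longer chain between the oxygen and the ring, or an alkyl group in place of the ring, also remains untested.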